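Substituent swap on the anilino ring of a pyrrolyl thiazolone ester

The compounds below may be only part of what the source reports. "The series", "measured", "known", "first", "only" and "open" are said of these compounds alone.

In a functional assay on JAR cells (Homo sapiens) for inhibition, read by MTT assay, with a stated time of 72 h, tested at 10 uM (on this read-out higher numbers stand for more inhibition at the one concentration tested (going by the name of the read-out) and lower numbers for less inhibition), three analogues sharing one core have been measured. Compound 1 `CCOC(=O)C1=C(Nc2ccc(Br)cc2)S/C(=C\c2ccc[nH]2)C1=O` gives 41.5%, compound 2 `CCOC(=O)C1=C(Nc2cccc(F)c2)S/C(=C\c2ccc[nH]2)C1=O` gives 45.4%, and compound 3 `CCOC(=O)C1=C(Nc2cccc([N+](=O)[O-])c2)S/C(=C\c2ccc[nH]2)C1=O` gives 57.4%, the highest of the three numbers, sitting a number 12 percentage points higher from compound 2 to compound 3 (beyond the scatter) and a number 15.9 percentage points higher from compound 1 to compound 3 (beyond the scatter), both beyond the scatter. The step of a number 3.9 percentage points higher from compound 1 to compound 2 (within the scatter) is within the scatter.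

Compound 4 `CCOC(=O)C1=C(Nc2ccc(C)cc2)S/C(=C\c2ccc[nH]2)C1=O` differs from compound 3 in a single place: 4-methylphenyl in place of 3-nitrophenyl on an amine nitrogen. Within the data shown here, no measured step covers this exact exchange. The two steps that bear on it are a number 15.9 percentage points higher from compound 1 to compound 3 (beyond the scatter) and a number 12 percentage points higher from compound 2 to compound 3 (beyond the scatter), which show that the 3-nitrophenyl analogue stands apart from the two halogen-bearing analogues. Compound 4 carries neither the nitro group nor a halogen, so the nearest guide is the cluster formed by compound 1 and compound 2. On that basis the number is expected to fall, with a step of a number 14.4 percentage points lower from compound 3 to compound 4 (beyond the scatter). Compound 4 is therefore estimated at 43% in this assay, within a range from 30% to 56%.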

Compound 4, a percentage reported as inhibition, at one concentration (the size of the read-out at that concentration, not a potency): < 10%
Compound 4: no number, only a limit; the forecaster's own chance of this, stated with the estimate: 2%; middle value at least 33 percentage points from the limit.
By their numbers in this assay, from the lowest: compounds 1 and 2 (each within the scatter of the next); then compound 3. At a limit, below all of these: compound 4.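

Compound 4 gives no number in this assay, only a limit: the limit of < 10% in this assay, at which 1 of the 4 values shown sits.

The fall is large against each analogue: a number at least 47.4 percentage points lower from compound 3 to compound 4 (beyond the scatter), a number at least 35.4 percentage points lower from compound 2 to compound 4 (beyond the scatter) and a number at least 31.5 percentage points lower from compound 1 to compound 4 (beyond the scatter). Among these compounds, the group on the amine nitrogen can therefore do far more than the earlier compounds showed, where exchanges there stayed within the scatter or were modest, and the single change of methyl in place of bromo on an aromatic carbon separates compound 1 from compound 4.

The compounds shown leave open whether the loss follows the methyl group itself, or whether a plain phenyl or a methoxy group on that ring would read the same way. They also do not separate group from ring place, as the 3-fluorophenyl and 3-nitrophenyl analogues have no direct counterparts among the 4-bromophenyl and 4-methylphenyl analogues.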